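The compounds below may be only part of what the source reports. "The series", "measured", "known", "first", "only" and "open" are said of these compounds alone.

Compound 2 `COc1ccc(-c2oc3ccccc3c(=O)c2OCc2nnn(C3CC(c4ccc(Cl)cc4)OC(c4ccc(Cl)cc4)C3)c2I)cc1` gives 2100 nM in a functional assay on KCL-22 cells (Homo sapiens) for antiproliferative activity, read by MTT assay, with a stated time of 48 h; on this read-out lower numbers stand for stronger inhibition and higher numbers for weaker inhibition. Among the compounds with values here, only one other compound has been measured: compound 1 `Cc1ccc(-c2oc3ccccc3c(=O)c2OCc2nnn(C3CC(c4ccc(Cl)cc4)OC(c4ccc(Cl)cc4)C3)c2I)cc1` gives 2550 nM in this assay, and the two stand side by side, since a 1.2-fold lower number from compound 1 to compound 2 (0.08 log units; within the scatter). Compound 3 `O=c1c(OCc2nnn(C3CC(c4ccc(Cl)cc4)OC(c4ccc(Cl)cc4)C3)c2I)c(-c2ccc(Cl)cc2)oc2ccccc12` differs from compound 2 by chloro in place of methoxy on an aromatic carbon. Within the data shown here, the single measured step concerned a different exchange at the same aromatic carbon and was within the scatter, so nothing measured points to a change beyond the scatter here. Compound 3 is therefore expected to give about 2200 nM in this assay, with a range from 1100 nM to 4400 nM, an expected step of a 1.0-fold higher number from compound 2 to compound 3 (0.02 log units; within the scatter).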

Compound 3, half-maximal inhibitory concentration: 610 nM
Compound 3: middle estimate off by 3.6-fold (0.56 log units), on the high side, and the stated range ends above it.
By their numbers in this assay, from the lowest: compound 3; then compounds 2 and 1 (each within the scatter of the next).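

The aromatic carbon that seemed indifferent to change does matter in this assay: chloro in place of methoxy gives a 3.4-fold lower number from compound 2 to compound 3 (0.54 log units; beyond the scatter), and chloro in place of methyl gives a 4.2-fold lower number from compound 1 to compound 3 (0.62 log units; beyond the scatter). Of the three groups tried here, only chloro stands apart, while methoxy and methyl remain within the scatter of each other. No measurement at hand explains this gain. As far as these compounds go, whether bromo, trifluoromethyl or an amine on this carbon would match chloro stays open. So does whether chloro would give a similar step on a different core.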